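A Cyclohexylmethyl Swap on Compound 3

This account rests on a few compounds, and the source may have more. Where it says the series, first, only, none or still open, it means among the compounds named here.

Compound 3 `CS(=O)(=O)Nc1ccc2c(c1)S(=O)(=O)N=C(c1c(O)c(-c3cccs3)nn(CC3(C(F)(F)F)CCC3)c1=O)N2` shares its core with compound 1 `COC(C)(C)CCn1nc(-c2cccs2)c(O)c(C2=NS(=O)(=O)c3cc(NS(C)(=O)=O)ccc3N2)c1=O` and compound 2 `CCCC(C)n1nc(-c2cccs2)c(O)c(C2=NS(=O)(=O)c3cc(NS(C)(=O)=O)ccc3N2)c1=O`, and all three have been tested in an ADME assay on Huh-7 cells (Homo sapiens) for cytotoxicity, with a stated time of 72 h; a lower number here means that less compound is tolerated, a higher number that more compound is tolerated. Compound 3 gives > 1000 nM, which is a limit and not a number. Compound 1 gives > 33000 nM, also a limit. Compound 2 gives > 33000 nM, again a limit. Compound 4 `CS(=O)(=O)Nc1ccc2c(c1)S(=O)(=O)N=C(c1c(O)c(-c3cccs3)nn(CCC3CCCCC3)c1=O)N2` differs from compound 3 in one place: cyclohexylmethyl in place of 1-(trifluoromethyl)cyclobutyl on a saturated chain carbon bound to an aromatic nitrogen. Cyclohexylmethyl stands in place of 1-(trifluoromethyl)cyclobutyl on a saturated chain carbon bound to an aromatic nitrogen. Two measured steps change this same side chain: a step that the two limits leave unreadable from compound 1 to compound 3, and a step that the two limits leave unreadable from compound 2 to compound 3. Neither offers a size to carry over, so no direction is expected from them, and no change beyond the usual scatter can be forecast in this assay. The estimated change is a step that the limit leaves unreadable from compound 3 to compound 4. The assay is expected to report only a limit more often than not. The expected value for compound 4 is 25000 nM, within an estimated range of 5000 nM to 60000 nM.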

Compound 4, half-maximal cytotoxic concentration: > 17000 nM
Compound 4 gave a limit, no number; the forecaster's own chance of this, stated with the estimate: 65%; the middle value is on the limit's open side.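

In this assay compound 4 gives > 17000 nM, which is a limit and not a number. Compound 1, compound 2 and compound 3 also give only limits, and no step among these four compounds can be read. The compounds shown leave open whether changing the side chain on the aromatic nitrogen shifts the tolerated concentration at all, and by how much.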